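This account rests on a few compounds, and the source may have more. Where it says the series, first, only, none or still open, it means among the compounds named here.

Of the compounds shown here, three with a shared core have been measured in a physicochemical assay for solubility, at pH 7.4; on this read-out lower numbers stand for lower solubility and higher numbers for higher solubility. Compound 1 `CCc1ccc(NC(=O)Nc2cc(C)nc3ccccc23)cc1` gives 3300 nM, the highest of the three numbers. Compound 3 `COc1ccc(NC(=O)Nc2cc(C)nc3ccccc23)cc1F` gives 2700 nM, which lies within the usual scatter of compound 1. Compound 2 `Cc1cc(NC(=O)Nc2cccc(C(N)=O)c2)c2ccccc2n1` gives 100 nM, far below compound 1 and well beyond the scatter.

Compound 4 `Cc1cc(NC(=O)Nc2ccc(OC(F)(F)F)cc2)c2ccccc2n1` has not yet been measured in this assay. It differs from compound 1 in one place: trifluoromethoxy in place of ethyl on an aromatic carbon. Going by the values given here, no measured pair shows this change, so the expectation rests on compound 1 alone. The step is expected to be small, with a slightly lower number for compound 4, hardly beyond the scatter. Compound 4 is estimated at 2000 nM, between 700 nM and 6000 nM, which means an expected step of a 1.7-fold lower number from compound 1 to compound 4 (0.22 log units; within the scatter).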

Compound 4, solubility: 300 nM
Compound 4: middle estimate off by 6.7-fold (0.82 log units), on the high side; the whole stated range lies above it.
By their numbers in this assay, from the lowest: compound 2; then compound 4; then compounds 3 and 1 (each within the scatter of the next).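

In this assay, the group on this aromatic carbon turns out to matter much more than compound 1 alone could suggest: trifluoromethoxy in place of ethyl gives an 11-fold lower number from compound 1 to compound 4 (1.04 log units; beyond the scatter). A single change at this position can therefore move the number well beyond the scatter. Nothing measured here accounts for a step of this size.

On these data alone, whether trifluoromethyl or an amine on this same carbon would give a step of similar size remains open. The parts played by the oxygen and the fluorine atoms of trifluoromethoxy therefore cannot yet be told apart.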